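This account rests on a few compounds, and the source may have more. Where it says the series, first, only, none or still open, it means among the compounds named here.

In an ADME assay (liver) for metabolic stability, with Liver microsome (Canis lupus familiaris) as the target, read by LC-MS, using microsomes, with a stated time of 30 min, tested at 4 uM (on this read-out higher numbers stand for a more stable compound and lower numbers for a less stable compound), compound 1 `CC(=O)NCCn1c(-c2ccccc2Cl)nc2c(N3CCN(C)CC3)nc(C)nc21` gives 40% and compound 2 `Cc1nc(N2CCN(C)CC2)c2nc(-c3ccccc3C(F)(F)F)n(C3CCOCC3)c2n1` gives 61% in the same test. Compound 2 therefore stands as the higher of the two numbers, and its gap to compound 1 lies beyond the usual scatter. These two compounds differ in more than one place, so the gap cannot be pinned on any single group.

Compound 3 `Cc1nc(N2CCN(C)CC2)c2nc(-c3ccccc3C)n(C3CCOCC3)c2n1` has not yet been measured and differs from compound 2 in one place. The change is methyl in place of trifluoromethyl on an aromatic carbon and in words it puts methyl in place of trifluoromethyl on an aromatic carbon, ortho to a large group, turning 2-(trifluoromethyl)phenyl into 2-methylphenyl.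

Within the data shown here, no measured pair shows this swap alone, so any forecast is loose. Among the measured compounds shown here, a modest fall is expected, about as large as the usual scatter, with compound 2 at 61% as the starting point and compound 1 at 40% as the only lower number seen so far. The estimated change is a number 11 percentage points lower from compound 2 to compound 3 (beyond the scatter) on this read-out. For compound 3 the estimated value is 50% with an expected range from 33% to 67% for the coming measurement.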

Compound 3, percent of the compound remaining: 39%
Compound 3: middle estimate off by 11 percentage points, on the high side; the range from low to high includes it.
By their numbers in this assay, from the lowest: compounds 3 and 1 (each within the scatter of the next); then compound 2.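

In this assay, putting methyl in place of trifluoromethyl on this aromatic carbon, ortho to a large group, gives a number 22 percentage points lower from compound 2 to compound 3 (beyond the scatter), so the read-out responds to what sits at this one position. Among these compounds, the earlier compounds offered no pair differing in one place, which makes this the first change in the set that can be tied to a single group, with the rest of the molecule held fixed. The result shows only the size and direction of the step, and no measurement at hand bears on why swapping these two groups lowers the number.

The compounds shown leave open whether other groups at this same position, such as a methoxy group, a nitrile or a single fluorine atom, would keep the number close to that of compound 2 or lower it as methyl does. They also leave open whether this swap gives a step of similar size in a different molecular setting, for example in a compound carrying the acetamide side chain of compound 1.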